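The source may report more compounds than this note shows. Statements on the series, on what has been measured and on what is new or still open speak of the compounds shown alone.

Compound 1 `O=[N+]([O-])c1cc(-c2nnn(Cc3cccc(Cl)c3)n2)cc([N+](=O)[O-])c1` and compound 2 `O=[N+]([O-])c1cc(-c2nnn(Cc3cccc(Br)c3)n2)cc([N+](=O)[O-])c1` were measured in an ADME assay on CHO-K1 cells (Cricetulus griseus) for cytotoxicity, read by MTT assay, with a stated time of 24 h; a higher number here means a weaker inhibitor, a lower number a stronger inhibitor: compound 1 gives 27000 nM and compound 2 gives 29000 nM.

Compound 2 stands alongside compound 1; the step of a 1.1-fold higher number from compound 1 to compound 2 (0.03 log units; within the scatter) shows the two numbers are within the scatter of each other. Compound 3 `O=[N+]([O-])c1cc(-c2nnn(Cc3ccccc3F)n2)cc([N+](=O)[O-])c1` differs from compound 2 by 2-fluorophenyl in place of 3-bromophenyl on a saturated chain carbon bound to an aromatic nitrogen. Among the compounds with values here, only one measured step bears on this change, a swap of one halogen for another on the same ring, and it was a 1.1-fold higher number from compound 1 to compound 2 (0.03 log units; within the scatter). Compound 3 is therefore expected to show no step beyond the scatter in this assay, a 1.0-fold lower number from compound 2 to compound 3 (0.02 log units; within the scatter). The estimate for compound 3 is 28000 nM, with a range from 14000 nM to 56000 nM.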

Compound 3, half-maximal inhibitory concentration: > 200000 nM
Compound 3 gave a limit, no number; the forecaster's own chance of this, stated with the estimate: 10%; middle value at least 7.1-fold (0.85 log units) away from the limit.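

In this assay, compound 3 gives only a limit, not a number: the limit of > 200000 nM in this assay, at which 1 of the 3 values shown sits. At this place, on a saturated chain carbon bound to an aromatic nitrogen, 2-fluorophenyl in place of 3-bromophenyl gives an at least 6.8-fold higher number from compound 2 to compound 3 (0.83 log units; beyond the scatter), and 2-fluorophenyl in place of 3-chlorophenyl gives an at least 7.4-fold higher number from compound 1 to compound 3 (0.86 log units; beyond the scatter). The earlier bromo for chloro swap gave only a 1.1-fold higher number from compound 1 to compound 2 (0.03 log units; within the scatter), so the ring at this place can shift the reading beyond the scatter. The compounds shown do not separate the change of halogen from the change in where it sits on the ring. On these data alone, how a ring carrying an amine or a carboxylic acid would read stays open.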